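Swapping the Hydroxy of Compound 2 for Phenyl

The source may report more compounds than this note shows. Statements on the series, on what has been measured and on what is new or still open speak of the compounds shown alone.

In a functional assay on MCF7 cells (Homo sapiens) for inhibition, read by MTT assay, with a stated time of 72 h, tested at 50 uM (on this read-out lower numbers stand for less inhibition of growth and higher numbers for more inhibition of growth at the one concentration tested), compound 1 (`C=CCc1cc(O)c(O)c(CN2CCC(C)CC2)c1`) gives 54.2%, and compound 2 (`C=CCc1cc(O)c(O)c(CN2CCC(CO)CC2)c1`) gives 32.3%, the lower of the two numbers. Compound 3 (`C=CCc1cc(O)c(O)c(CN2CCC(Cc3ccccc3)CC2)c1`) differs from compound 2 by phenyl in place of hydroxy on a saturated chain carbon bound to a saturated ring carbon. Going by the values given here, the only measured step bearing on this is a number 21.9 percentage points lower from compound 1 to compound 2 (beyond the scatter), which came with that hydroxy in place of hydrogen. With the hydroxy gone, a rise of similar size is expected, an estimated a number 24.7 percentage points higher from compound 2 to compound 3 (beyond the scatter). The expected value for compound 3 is 57%, with an estimated range from 38% to 76%.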

Compound 3, percent growth inhibition at one concentration: 86.3%
Beside the measured number, compound 3's estimate is 29.3 percentage points below it; the measured number lies above the stated range.
By their numbers in this assay, from the lowest: compound 2; then compound 1; then compound 3.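

In this assay, the place on a saturated chain carbon bound to a saturated ring carbon proves able to raise the number as well as lower it: phenyl in place of hydroxy gives a number 54 percentage points higher from compound 2 to compound 3 (beyond the scatter), and phenyl in place of hydrogen gives a number 32.1 percentage points higher from compound 1 to compound 3 (beyond the scatter). The change thus goes well past simply removing the hydroxy, and compound 3 stands highest of the three. No measurement shown accounts for this rise.

From the compounds shown here alone, whether the phenyl ring itself is needed stays open. Going by these compounds, how a longer alkyl chain, an amine or a carboxylic acid would compare at this place also remains unknown.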